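This account rests on a few compounds, and the source may have more. Where it says the series, first, only, none or still open, it means among the compounds named here.

Measured so far:
- compound 1 `COc1cc2ncnc(-n3nc(-c4ccccn4)nc3N)c2cc1OCCCN1CC(C)OC(C)C1`: 8000 nM
- compound 2 `COc1cc2ncnc(-n3nc(-c4ccccn4)nc3N)c2cc1OCCNC(=O)OC(C)(C)C`: 2000 nM

In a physicochemical assay for solubility, in phosphate buffer, with a stated time of 18 h, at pH 7.4 (on this read-out lower numbers stand for lower solubility and higher numbers for higher solubility), compound 2 gives 2000 nM, the lower of the two numbers. Compound 3 `CCCCCCOC(=O)NCCCOc1cc2c(-n3nc(-c4ccccn4)nc3N)ncnc2cc1OC` is the next to be read: ((hexyloxycarbonyl)amino)methyl in place of (tert-butoxycarbonyl)amino on a saturated chain carbon, two bonds along the chain from an oxygen on an aromatic ring. It carries ((hexyloxycarbonyl)amino)methyl in place of (tert-butoxycarbonyl)amino on a saturated chain carbon, two bonds along the chain from an oxygen on an aromatic ring. For the measured compounds named here, the only measured step, a 4.0-fold lower number from compound 1 to compound 2 (0.60 log units; beyond the scatter), is modest and involves a different exchange, so it offers only a loose guide to size. A modest move to a lower number is expected, with an estimated 2.9-fold lower number from compound 2 to compound 3 (0.46 log units; beyond the scatter). The expected value for compound 3 is 700 nM, within an estimated range of 150 nM to 2500 nM.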

Compound 3, solubility: 1000 nM
Compound 3: middle estimate off by 1.4-fold (0.15 log units), on the low side, within the range that was stated.
By their numbers in this assay, from the lowest: compounds 3 and 2 (each within the scatter of the next); then compound 1.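

In this assay ((hexyloxycarbonyl)amino)methyl in place of (tert-butoxycarbonyl)amino gives a 2.0-fold lower number from compound 2 to compound 3 (0.30 log units; within the scatter) and so the two groups are not told apart at this position. Compound 3 still stands clear of compound 1: (hexyloxycarbonyl)amino in place of 2,6-dimethylmorpholin-4-yl gives an 8.0-fold lower number from compound 1 to compound 3 (0.90 log units; beyond the scatter) and the separation from compound 1 now holds for two different chain ends. Nothing given here accounts for these numbers.

Open, going by these compounds, is where a primary amine or a carboxylic acid at the chain end would fall relative to compound 1. Also open, on these data alone, is whether a longer chain than hexyl would separate from compound 2 and compound 3.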